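Formyl on the aromatic-ring nitrogen of compound 1

A few compounds are considered here, and "the series" means these few. Any claim that something is new, unique, unknown or untested is made for them only; others in the source may bear on it.

Measured so far:
compound 1 `Cc1nc2c(OCc3ccccc3)cccn2c1N`: 97%
compound 2 `Cc1nc2c(OCc3ccsc3)cccn2c1N`: 82%

In a functional assay on the whole organism with Canis familiaris (Canis lupus familiaris) as the target, at a dose of 2 mg/kg by the intravenous route (a higher number here means a stronger effect of the compound at the dose given, a lower number a weaker effect), compound 1 gives 97%, the highest of the two numbers available. For the measured compounds named here, compound 2 gives 82%, and the one measured step, a number 15 percentage points lower from compound 1 to compound 2 (beyond the scatter), concerns only the ring on the saturated chain carbon bound to the oxygen on the aromatic ring.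

Compound 3 `Cc1nc2c(OCc3ccccc3)cccn2c1NC=O` differs from compound 1 by formyl in place of hydrogen on a nitrogen on an aromatic ring. Going by the values given here, no measured step touches the nitrogen on the aromatic ring, so the step of a number 15 percentage points lower from compound 1 to compound 2 (beyond the scatter) does not bear on this change and the direction of the effect cannot be read from the series. Among the compounds with values here, two points frame the expectation: compound 1 already stands near the top of the read-out, which leaves little room upward, and a change on a nitrogen that has not yet been varied could move the number downward by more than the scatter. The expected step is therefore a number 12 percentage points lower from compound 1 to compound 3 (beyond the scatter), with a wide range. Compound 3 is estimated to give 85% in this assay, between 55% and 98%.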

Compound 3, a percentage reported as inhibition, in the whole organism at one dose (the size of the read-out at that dose, not a potency): 3%
Compound 3: middle estimate off by 82 percentage points, on the high side, and the stated range ends above it.
By their numbers in this assay, from the lowest: compound 3; then compound 2; then compound 1.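

In this assay, the change from amino to formylamino gives a number 94 percentage points lower from compound 1 to compound 3 (beyond the scatter), making this nitrogen the first place in the series where a single change leaves almost none of the effect at the dose given. The earlier step, a number 15 percentage points lower from compound 1 to compound 2 (beyond the scatter), concerned only the ring on the saturated chain carbon and left most of the effect in place, whereas here formyl, with only 2 heavy atoms and no ring, takes the place of a hydrogen and produces a far larger step. Nothing available explains this loss of effect.

As far as these compounds go, it remains open whether the loss is specific to formyl or extends to other groups on this nitrogen, and an acetyl group or a single methyl group there would help separate these possibilities. Also open, from the compounds shown here alone, is whether formylamino has the same outcome with thiophen-3-yl in place of phenyl, and how the effect of formylamino would read at doses other than the single one given.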